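Replacing the Aryl Thiourea Arm of Compound 3

The source may hold more compounds than are shown below. What is called first, only, known or untested is meant among the compounds shown, and "the series" means these compounds.

Of the compounds shown here, three built on one shared core have been measured in a functional assay on Ehrlich cells (Mus musculus) for cytotoxicity, read by trypan blue exclusion, with a stated time of 2 h, tested at 25 ug/mL; a higher number here means a stronger effect of the compound at the concentration tested, a lower number a weaker effect. Compound 1 `N#CC1=C(N)N(c2ccc(S(N)(=O)=O)cc2)C2=C(C(=O)CCC2)C1c1ccc(Cl)cc1Cl` gives 50%. Compound 2 `N#CC1=C(NC(=S)Nc2ccc(Cl)cc2)N(c2ccc(S(N)(=O)=O)cc2)C2=C(C(=O)CCC2)C1c1ccc(Cl)cc1Cl` gives 60%, and compound 3 `N#CC1=C(NC(=S)Nc2ccc(Br)cc2)N(c2ccc(S(N)(=O)=O)cc2)C2=C(C(=O)CCC2)C1c1ccc(Cl)cc1Cl` gives 50%. Compound 3 thus stands level with compound 1, the two together making up the lowest of the three numbers; its nearest neighbour is compound 1 with no change at the digits printed from compound 1 to compound 3 (within the scatter), and compound 2 lies furthest at a number 10 percentage points lower from compound 2 to compound 3 (within the scatter). None of these steps leaves the scatter.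

Compound 4 `N#CC1=C(N2C(=O)CCC2=O)N(c2ccc(S(N)(=O)=O)cc2)C2=C(C(=O)CCC2)C1c1ccc(Cl)cc1Cl` differs from compound 3 in one place: a group of 7 heavy atoms (4 carbon, 1 nitrogen, 2 oxygen; one five-membered non-aromatic ring with 1 hetero atom) in place of a group of 11 heavy atoms (7 carbon, 2 nitrogen, 1 sulfur, 1 bromine; one six-membered aromatic ring of carbon only), on a double-bonded ring carbon. The measured steps that bear on this are the two that attached a group of the same kind to compound 1, namely a number 10 percentage points higher from compound 1 to compound 2 (within the scatter) and no change at the digits printed from compound 1 to compound 3 (within the scatter), both within the scatter. Taking such a group away is therefore not expected to shift the reading in this assay beyond the scatter, while the entering ring has no counterpart among the measured compounds. Compound 4 is expected to give about 50% in this assay, between 35% and 65%. The expected step is no change at the digits printed from compound 3 to compound 4 (within the scatter).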

Compound 4, a percentage reported as activity, at one concentration (the size of the read-out at that concentration, not a potency): 50%
The estimate for compound 4 equals the measured number at the digits printed; low and high end bracket the measured number.
By their numbers in this assay, from the lowest: compounds 1, 3, 4 and 2 (each within the scatter of the next).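

On the double-bonded ring carbon, the 2,5-dioxopyrrolidin-1-yl group departs from both the amino group and the aryl thiourea arms, yet this assay shows no change at the digits printed from compound 3 to compound 4 (within the scatter) and a number 10 percentage points lower from compound 2 to compound 4 (within the scatter) and no change at the digits printed from compound 1 to compound 4 (within the scatter). The position therefore takes a five-membered non-aromatic ring with no hydrogen-bond donors, in place of an arm carrying a six-membered aromatic ring of carbon only, without any step leaving the scatter. Nothing available accounts for this reading.

As far as these compounds go, whether a carboxylic acid, a morpholine ring or a longer alkyl chain on this carbon would give a step beyond the scatter remains open. The readings also come from one concentration, leaving open whether these four compounds differ in potency.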